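Plasma Protein Binding of Cyclic Sulfoximine Amides

The compounds below may be only part of what the source reports. "The series", "measured", "known", "first", "only" and "open" are said of these compounds alone.

Compound 1 `N=S1(=O)c2ccccc2C(=O)N1c1ccccc1`: "not determined" (no result reported) in an ADME assay on a cell-free system (plasma, Homo sapiens) for protein binding; a lower number here means a smaller unbound share, a higher number a larger unbound share of the compound
Compound 2 `CCN=S1(=O)NC(=O)c2ccccc21`: 0.41
Compound 3 `N=S1(=O)c2ccccc2C(=O)N1Cc1ccccc1`: "not determined" (no result reported) in this assay

Three compounds share one core, and only one of them carries a number. In this assay compound 2 gives 0.41. Among the measured compounds shown here, compound 1 gives "not determined" (no result reported) and compound 3 gives "not determined" (no result reported) in this assay, so compound 3 stands nowhere on the numbers: neither a value nor a limit is known for it, and no step from it to any other compound can be counted.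

Compound 4 `CCN1C(=O)c2ccccc2S1(=N)=O` differs from compound 3 in one place: methyl in place of phenyl on a saturated chain carbon bound to an amide-type nitrogen in a ring. For the measured compounds named here, no measured pair shows this change, so its size in this assay is not known from the data. The expectation is for a move toward a larger unbound share, of a size that may reach somewhat beyond the usual scatter, with the direction resting only on the character of the group that leaves and the one that enters.

Going by the values given here, for compound 4 the unbound fraction in this assay is estimated at 0.5, within a range of 0.28 to 0.85, an estimate anchored mainly on compound 2 because it gives 0.41 and is the sole measured compound of the set.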

Compound 4, unbound fraction in the plasma assay: 0.83
Beside the measured number, compound 4's estimate is 1.7-fold (0.22 log units) below it, within the range that was stated.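

Among the compounds shown here, in the plasma assay no step from compound 3 to compound 4 can be read, as compound 3 has no number there. In a physicochemical assay for acid dissociation, read by spectrophotometry, compound 3 gives 8.7 and compound 4 gives 8.9, which is a number 0.20 log units higher from compound 3 to compound 4 (within the scatter). Nothing shown bears on the cause of these results. The compounds shown leave open how far methyl in place of phenyl shifts the unbound fraction.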